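Amide chain variation on the shared core, aryl end

The compounds below may be only part of what the source reports. "The series", "measured", "known", "first", "only" and "open" are said of these compounds alone.

Measured so far:
compound 1 `O=C(CCCc1ccccc1)Nc1nc2ccccc2c(=O)s1`: 186 nM
compound 2 `O=C(CCCc1ccc(Cl)c(Cl)c1)Nc1nc2ccccc2c(=O)s1`: 3300 nM

In an assay on mitochondria (strain Sprague-Dawley) for inhibition of Amine oxidase [flavin-containing] B (Rattus norvegicus), read by fluorescence and Amplex Red, with stated times of 30 min and 45 min (a lower number here means a stronger inhibitor, a higher number a weaker inhibitor), compound 2 stands highest of the two numbers; its nearest neighbour is compound 1, with an 18-fold higher number from compound 1 to compound 2 (1.25 log units; beyond the scatter). Compound 3 `COc1cccc(CCCC(=O)Nc2nc3ccccc3c(=O)s2)c1` differs from compound 2 by 3-methoxyphenyl in place of 3,4-dichlorophenyl on a saturated chain carbon, three bonds along the chain from a carbonyl carbon. Among the compounds with values here, only the step from compound 1 to compound 2 bears on this change, and it was large, upward; compound 3 carries a substituted ring too, but a different one. The number for compound 3 is expected to fall between those of compound 1 and compound 2, estimated at 700 nM (range 150 nM to 3000 nM), that is a 4.7-fold lower number from compound 2 to compound 3 (0.67 log units; beyond the scatter).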

Compound 3, half-maximal inhibitory concentration: 1300 nM
Estimate against measurement, compound 3: 1.9-fold (0.27 log units) below; measured number inside the range.
By their numbers in this assay, from the lowest: compound 1; then compound 3; then compound 2.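

In this assay the exchange of 3,4-dichlorophenyl for 3-methoxyphenyl on the saturated chain carbon gives a 2.5-fold lower number from compound 2 to compound 3 (0.40 log units; beyond the scatter) and so regains only part of the earlier loss. Methoxy in place of hydrogen on an aromatic carbon still gives a 7.0-fold higher number from compound 1 to compound 3 (0.84 log units; beyond the scatter) and leaves both substituted rings shown weaker than the plain phenyl of compound 1. No measurement at hand explains the gap between these rings.

Open, from the compounds shown here alone, is whether a hydroxy group, an amine or a single chlorine on the ring would also weaken inhibition. Going by these compounds, a longer chain carrying 3-methoxyphenyl also remains untested here.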